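The source may report more compounds than this note shows. Statements on the series, on what has been measured and on what is new or still open speak of the compounds shown alone.

Measured in a functional assay on MCF7 cells (Homo sapiens) for cytotoxicity, read by MTT assay, with a stated time of 24 h; a lower number here means a stronger inhibitor, a higher number a weaker inhibitor:
compound 1 `CCNc1cc(-c2ccc(NC(=O)Nc3cccc(Cl)c3)cc2C)ccn1`: 4180 nM
compound 2 `CCNc1cc(-c2ccc(NC(=O)Nc3ccc(OC)cc3)cc2C)ccn1`: 9950 nM
compound 3 `CCNc1cc(-c2ccc(NC(=O)Nc3c(C)cccc3C)cc2C)ccn1`: 7920 nM

Compound 2 lies at the upper end of these three numbers, though not clear of compound 3. The step of a 1.3-fold lower number from compound 2 to compound 3 (0.10 log units; within the scatter) stays within the scatter, while a 2.4-fold higher number from compound 1 to compound 2 (0.38 log units; beyond the scatter) goes beyond it.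

The next compound, compound 4 `CCNc1cc(-c2ccc(NC(=O)Nc3ccc(OC)cc3)cc2OC)ccn1`, keeps the 4-methoxyphenyl group of compound 2 and has methoxy in place of methyl on an aromatic carbon, ortho to a 2-(ethylamino)pyridin-4-yl group: methoxy in place of methyl on an aromatic carbon.

Among the compounds with values here, no measured pair changes this position. All three steps concern the group on the amide-type nitrogen, so they bear on the question only indirectly, by showing how little the numbers have moved. Besides the modest step above, a 1.9-fold higher number from compound 1 to compound 3 (0.28 log units; within the scatter) also lies within the scatter. In this assay, no step beyond the scatter is therefore expected, and no direction can be argued with confidence.

The expected change is a 1.1-fold lower number from compound 2 to compound 4 (0.04 log units; within the scatter). For compound 4 the estimated value is 9000 nM, with an expected range from 4000 nM to 20000 nM.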

Compound 4, half-maximal inhibitory concentration: 17500 nM
Compound 4: the middle estimate sits 1.9-fold (0.29 log units) below what was measured; low and high end bracket the measured number.
By their numbers in this assay, from the lowest: compounds 1, 3, 2 and 4 (each within the scatter of the next, the first and the last beyond it).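

Within the data shown here, compound 2 and compound 4 form the first measured pair that touches the aromatic carbon ortho to a 2-(ethylamino)pyridin-4-yl group, with the 4-methoxyphenyl group on the amide-type nitrogen held fixed. In this assay, methoxy in place of methyl gives a 1.8-fold higher number from compound 2 to compound 4 (0.25 log units; within the scatter), so this single pair does not separate the two groups at this position. No accompanying evidence bears on this step, and the result therefore carries no explanation.

The compounds shown leave open whether a different group at this position, such as fluorine, a hydroxyl or an amine, would produce a step beyond the scatter. They also leave open whether methoxy in place of methyl would read the same alongside the 3-chlorophenyl or 2,6-dimethylphenyl group.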